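A few compounds are considered here, and "the series" means these few. Any claim that something is new, unique, unknown or untested is made for them only; others in the source may bear on it.

In an assay on isolated protein for inhibition of phosphodiesterase 4A (Sus scrofa) (on this read-out lower numbers stand for stronger inhibition and higher numbers for weaker inhibition), compound 1, with the structure `COc1ccc(C(=O)Nc2ccccc2Cl)cc1OC1CCCC1`, gives 190 nM. Within the data shown here, of the two numbers measured so far this is the lower one; its nearest neighbour is compound 2, whose structure is `COc1ccc(C(=O)Nc2ccccc2F)cc1OC1CCCC1` and which in this assay gives 10700 nM, so the step of a 56-fold higher number from compound 1 to compound 2 (1.75 log units; beyond the scatter) is a large one, and it comes from the change of fluoro in place of chloro on an aromatic carbon.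

Compound 3, with the structure `COc1ccc(C(=O)Nc2ccccc2Cl)cc1OC(C)=O`, has not yet been measured in this assay. It differs from compound 1 at a different place than compound 2 does: acetyl in place of cyclopentyl on an oxygen on an aromatic ring. No measured step touches this part of the shared core, since the only step shown concerns the halogen on the other ring. There is therefore nothing measured to lean on, and the size and direction of the step in this assay cannot be read off the data; the expectation below rests on that gap and is deliberately wide.

The expected step from compound 1 to compound 3 is a 16-fold higher number from compound 1 to compound 3 (1.20 log units; beyond the scatter). For compound 3 the estimated value in this assay is 3000 nM, within a range from 400 nM to 30000 nM.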

Compound 3, half-maximal inhibitory concentration: 70000 nM
Compound 3: the middle estimate sits 23-fold (1.37 log units) below what was measured; the whole stated range lies below it.
By their numbers in this assay, from the lowest: compound 1; then compound 2; then compound 3.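

In this assay, the group on this oxygen matters a great deal: acetyl in place of cyclopentyl gives a 370-fold higher number from compound 1 to compound 3 (2.57 log units; beyond the scatter) and is a large step, so this part of the core is just as sensitive as the halogen on the other ring, where the earlier change gave a 56-fold higher number from compound 1 to compound 2 (1.75 log units; beyond the scatter). Of the two single changes made to compound 1, each moves the number up, and compound 1 keeps the lowest value of the three. However, this one swap alters several things together, since a five-membered carbon ring leaves and a smaller group with no ring, a double bond and a hydrogen-bond acceptor enters, and nothing available explains how any of these relates to the size of the step.

The compounds shown leave open whether losing the ring or gaining the carbonyl counts for more, which an ethyl group or a cyclohexyl group on the same oxygen would begin to separate. Going by these compounds, it also remains open whether any group on this oxygen, such as a benzyl group or a chain ending in an amine, would give a lower number than cyclopentyl does.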